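From a Benzyl Arm to a 4-Ethylphenyl Arm

The compounds below may be only part of what the source reports. "The series", "measured", "known", "first", "only" and "open" are said of these compounds alone.

compound 1, `C=C(Br)C(=O)Nc1cccc(-c2cn3nc(CCc4ccccc4)sc3n2)c1`: 2600 nM
compound 2, `C=C(Br)C(=O)Nc1cccc(-c2cn3nc(Cc4ccc(OC)cc4)sc3n2)c1`: 850 nM
compound 3, `C=C(Br)C(=O)Nc1cccc(-c2cn3nc(Cc4ccccc4)sc3n2)c1`: 3000 nM

Of the compounds shown here, three sharing one core have been measured in a functional assay on FM3A cells (Mus musculus) for inhibition, read by cell counting, with a stated time of 2 days; on this read-out higher numbers stand for weaker inhibition and lower numbers for stronger inhibition. Compound 3 gives 3000 nM, the highest of the three numbers. The nearest of the other numbers lies within the scatter, a 1.2-fold higher number from compound 1 to compound 3 (0.06 log units; within the scatter), so no order can be read between those two. The furthest number is separated by a modest step, a 3.5-fold higher number from compound 2 to compound 3 (0.55 log units; beyond the scatter).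

Compound 4, `C=C(Br)C(=O)Nc1cccc(-c2cn3nc(-c4ccc(CC)cc4)sc3n2)c1`, has not yet been measured. Against compound 3 it differs in one place: 4-ethylphenyl in place of benzyl on an aromatic carbon. Among the compounds with values here, no measured step puts an aryl group straight onto the core; the closest evidence is the pair of steps that add or remove a substituent on the benzyl ring, a 3.1-fold lower number from compound 1 to compound 2 (0.49 log units; beyond the scatter) and a 3.5-fold higher number from compound 2 to compound 3 (0.55 log units; beyond the scatter), both modest, and the step that changes the chain length, a 1.2-fold higher number from compound 1 to compound 3 (0.06 log units; within the scatter), which stayed within the scatter. A modest lowering of the number, or none beyond the scatter, is therefore expected, and the step of a 2.0-fold lower number from compound 3 to compound 4 (0.30 log units; within the scatter) is the estimate. Compound 4 is expected to give 1500 nM, with a range of 500 nM to 4500 nM.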

Compound 4, half-maximal inhibitory concentration: 3300 nM
Compound 4: middle estimate off by 2.2-fold (0.34 log units), on the low side, within the range that was stated.
By their numbers in this assay, from the lowest: compound 2; then compounds 1, 3 and 4 (each within the scatter of the next).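

In this assay the aromatic carbon next to the ring nitrogen and the ring sulfur carries 4-ethylphenyl as readily as it carries benzyl (a 1.1-fold higher number from compound 3 to compound 4 (0.04 log units; within the scatter)) or phenethyl (a 1.3-fold higher number from compound 1 to compound 4 (0.10 log units; within the scatter)), so an aryl ring bound directly to the core gives a number that cannot be told apart from those of the two unsubstituted chain-linked arms. Within the data shown here, the para-free comparison that stands out remains the one with the 4-methoxybenzyl group (a 3.9-fold higher number from compound 2 to compound 4 (0.59 log units; beyond the scatter)), which shows that a substituted ring at this position does not by itself bring the lower number of compound 2: the ethyl-bearing ring of compound 4 does not share it. Nothing available explains why these groups compare as they do.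

This change removes the linking carbon and adds the ethyl group in one move, so the compounds shown cannot separate the two, and the effect of either alone remains unknown. From the compounds shown here alone, it also remains open how an unsubstituted phenyl or a 4-methoxyphenyl bound directly to this carbon would compare, and whether the methoxy group keeps its effect without the linking carbon.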